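This account rests on a few compounds, and the source may have more. Where it says the series, first, only, none or still open, it means among the compounds named here.

Measured compounds:
- compound 1, `COc1ccc(-c2cc3ccccc3c(-c3cccc(N)c3)n2)cc1`, in a functional assay on T47D cells (Homo sapiens) for cytotoxicity, read by CCK-8 assay and cell counting, with a stated time of 72 h (on this read-out higher numbers stand for weaker inhibition and lower numbers for stronger inhibition), gives 950 nM
- compound 2, `COc1ccc(-c2cc3ccccc3c(-c3ccc(O)cc3)n2)cc1`, in this assay gives 1220 nM
- compound 3, `COc1ccc(-c2cc3cc(C)ccc3c(-c3cccc(N)c3)n2)cc1OC`, in this assay gives 450 nM

Compound 3 has the lowest of the three numbers, and its gaps to compound 1 and to compound 2 are both beyond the usual scatter. Compound 1 and compound 2 differ in a single place, (4-hydroxyphenyl in place of 3-aminophenyl on an aromatic carbon), and that change gave a 1.3-fold higher number from compound 1 to compound 2 (0.11 log units; within the scatter).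

Compound 4, `COc1ccc(-c2cc3cc(C)ccc3c(-c3ccc(O)cc3)n2)cc1OC`, has not yet been measured. It is made from compound 3 by one change, (4-hydroxyphenyl in place of 3-aminophenyl on an aromatic carbon). This is the same kind of change as the one already measured, though the surroundings are not described identically: for compound 1 the place is said to be meta to a 4-methoxyphenyl group (8 heavy atoms), whereas for compound 3 it is said to be meta to a large group. How the core of compound 3 differs from the core of compound 1 is not broken down here.

For the measured compounds named here, the one measured example of this kind of change stayed within the scatter. On that basis the step from compound 3 to compound 4 in this assay is expected to be small, about a 1.3-fold higher number from compound 3 to compound 4 (0.11 log units; within the scatter). This rests on compound 3 at 450 nM together with the earlier step of a 1.3-fold higher number from compound 1 to compound 2 (0.11 log units; within the scatter). Compound 4 is therefore estimated at 580 nM, with a likely range from 280 nM to 1200 nM.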

Compound 4, half-maximal inhibitory concentration: 4420 nM
Compound 4: middle estimate off by 7.6-fold (0.88 log units), on the low side; the whole stated range lies below it.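

In this assay, putting 4-hydroxyphenyl in place of 3-aminophenyl gave a 9.8-fold higher number from compound 3 to compound 4 (0.99 log units; beyond the scatter), and this step does not match the one seen with the same change on the other core: the same change on two cores in this assay, a 1.3-fold higher number (0.11 log units; within the scatter) from compound 1 to compound 2 and a 9.8-fold higher number (0.99 log units; beyond the scatter) from compound 3 to compound 4, 7.6-fold (0.88 log units) apart, beyond the scatter of two such steps For these two pairs, then, the size of the change depended on the core that carried it, and the small earlier step was not a safe guide to the later one. This does not show which difference between the two cores matters, since the core of compound 3 carries both a methyl group and a second methoxy group that the core of compound 1 lacks, nor does it explain why the step is so much larger on that core or give a rule for any further core.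

The compounds shown leave open whether the methyl group or the second methoxy group alone would be enough to produce the larger step, which a core carrying only one of them could settle. They also leave open how other groups at this place would behave on both cores, such as a plain phenyl ring or a phenyl ring bearing a carboxylic acid.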